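A few compounds are considered here, and "the series" means these few. Any claim that something is new, unique, unknown or untested is made for them only; others in the source may bear on it.

Working notes on the series. Compound 1 `Cc1cc(NC(=O)Cn2nnc(-c3ccccc3)n2)n(C2CCOCC2)n1` carries oxan-4-yl on an aromatic nitrogen of the shared core; in an assay on HEK293 cells for activation of Kir3.1/Kir3.2 (Homo sapiens), read by thallium flux (a lower number here means a smaller maximal response, a higher number a larger maximal response), compound 1 gives 115%. Compound 2 `Cc1cc(NC(=O)Cn2nnc(-c3ccccc3)n2)n(C2CCC(C)(C)CC2)n1` carries 4,4-dimethylcyclohexyl at that position instead. For compound 2 this assay reports only a limit, > 19%, and no number. The step that the limit leaves unreadable from compound 1 to compound 2 is accordingly not readable in size or direction, and compound 2 stands on the numbers only as a compound to which the limit of > 19% in this assay, at which 1 of the 2 values shown sits, applies. Compound 3 `CCC(C)n1nc(C)cc1NC(=O)Cn1nnc(-c2ccccc2)n1` is not yet measured; it differs from compound 2 by sec-butyl in place of 4,4-dimethylcyclohexyl on an aromatic nitrogen. For the measured compounds named here, no measured step bears on this change: the only measured step, a step that the limit leaves unreadable from compound 1 to compound 2, is itself unreadable due to the limit of > 19% in this assay, at which 1 of the 2 values shown sits, and it concerns a different pair of groups. An expectation for compound 3 therefore rests only on the two values shown, a full response for compound 1 and a limit for compound 2, and is wide. Compound 3 is expected at 70%, between 20% and 120%. For compound 3 this means an expected step that the limit leaves unreadable from compound 2 to compound 3, which cannot be set against a readable number.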

Compound 3, largest response reached (Emax), in percent of the reference or control that the assay uses: > 69%
Compound 3 was reported as a limit (the forecaster's own chance of this, stated with the estimate: 30%); the middle value lies beyond the limit too.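

In this assay compound 3 gives > 69%, which is a limit and not a number. The steps joining compound 1, compound 2 and compound 3 therefore cannot be read. The compounds shown leave open the actual maximal responses of compound 2 and compound 3, and whether sec-butyl, 4,4-dimethylcyclohexyl and oxan-4-yl differ at this position.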